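The compounds below may be only part of what the source reports. "The series", "measured", "known", "first", "only" and "open" are said of these compounds alone.

Working notes on the series. In a functional assay on HCT-116 cells (Homo sapiens) for antiproliferative activity, read by MTT assay, with a stated time of 48 h (on this read-out higher numbers stand for weaker inhibition and lower numbers for stronger inhibition), compound 1 `COc1cc(C(=O)/C=C/c2ccc(OCCCC(=O)NCCCNCCCCN)cc2)cc(OC)c1OC` gives > 100000 nM, which is a limit and not a number. Compound 2 `COc1ccc(/C=C/C(=O)c2cc(OC)c(OC)c(OC)c2)cc1OCCCC(=O)NCCCNCCCCN` gives > 100000 nM, which is also a limit. Among the compounds with values here, the series so far stands at the limit of > 100000 nM in this assay, at which 2 of the 2 values shown sit. Compound 3 `COc1cc(C(=O)/C=C/c2ccc(OCCCC(=O)NCCCCNCCCN)cc2)cc(OC)c1OC` has the same atoms as compound 1, joined differently: ((3-aminopropyl)amino)methyl in place of (4-aminobutyl)amino on a saturated chain carbon, three bonds along the chain from an amide-type nitrogen. Within the data shown here, no measured pair gives a size for this change, and no step beyond the scatter is expected in this assay, in either direction. The estimated step is a number no higher from compound 1 to compound 3 (the limit leaves the size open). For compound 3 the expected value is 100000 nM, with an estimated range of 40000 nM to 200000 nM.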

Compound 3, half-maximal inhibitory concentration: 20000 nM
Estimate against measurement, compound 3: 5.0-fold (0.70 log units) above; the measured number lies below the stated range.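

In this assay, ((3-aminopropyl)amino)methyl in place of (4-aminobutyl)amino on a saturated chain carbon gives an at least 5.0-fold lower number from compound 1 to compound 3 (0.69 log units; beyond the scatter). The two groups hold the same counted atoms, so how the chain is joined at this place is enough to bring a measurable number into the series. The full size of the step stays open because compound 1 sits at a limit: the limit of > 100000 nM in this assay, at which 2 of the 3 values shown sit.

The compounds shown leave open whether the same change would act alike on compound 2, and whether a longer chain or a carboxylic acid at this place would move the number further.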